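This account rests on a few compounds, and the source may have more. Where it says the series, first, only, none or still open, it means among the compounds named here.

Measured compounds in an ADME assay on a cell-free system (plasma, Homo sapiens) for metabolic stability, read by LC-MS; a lower number here means that the compound disappears faster, a higher number that the compound lasts longer:
- compound 1 `CC(C)OC(=O)c1cccc(NC(=O)c2cccc(-c3cc(C(=O)Nc4ccncc4F)ccc3CN)c2)c1`: 0.567 h
- compound 3 `CCC(C)OC(=O)c1cccc(NC(=O)c2cccc(-c3cc(C(=O)Nc4ccncc4F)ccc3CN)c2)c1`: 0.267 h
- compound 2 `NCc1ccc(C(=O)Nc2ccncc2F)cc1-c1cccc(C(=O)OCC2CCCO2)c1`: a limit of the assay, < 0.0834 h

Compound 1 stands highest of the two numbers given in this assay; its nearest neighbour is compound 3, with a 2.1-fold lower number from compound 1 to compound 3 (0.33 log units; beyond the scatter). For compound 2 only a limit is known, (the limit of < 0.0834 h in this assay, at which 1 of the 3 values shown sits), so it sets no number against compound 1.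

Compound 4 `NCc1ccc(C(=O)Nc2ccncc2F)cc1-c1cccc(C(=O)Nc2ccccc2)c1` differs from compound 1 by hydrogen in place of isopropoxycarbonyl on an aromatic carbon. Going by the values given here, the only measured step that touches this part of the molecule is the one from compound 1 to compound 3, where methyl in place of hydrogen on the saturated chain carbon of the isopropoxycarbonyl group gave a modest, beyond-scatter move downward. Among the compounds with values here, that step changed only the alkyl part of the group; the step to compound 4 removes the whole isopropoxycarbonyl group, and no measured pair shows that change. The measured step argues that this region is sensitive in this assay, but its direction for a full removal cannot be read from the pair shown.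

The estimate for compound 4 is therefore held wide, with the number expected to move upward, a 2.6-fold higher number from compound 1 to compound 4 (0.42 log units; beyond the scatter). The expected half-life for compound 4 is 1.5 h, within 0.4 h to 6 h.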

Compound 4, half-life: > 2 h
Compound 4: a limit, no number; the forecaster's own chance of this, stated with the estimate: 20%; at least 1.3-fold (0.12 log units) between middle value and limit.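

In this assay, hydrogen on this aromatic carbon gives an at least 3.5-fold higher number from compound 1 to compound 4 (0.54 log units; beyond the scatter) and an at least 7.4-fold higher number from compound 3 to compound 4 (0.87 log units; beyond the scatter), so the change now covers the whole group, where a 2.1-fold lower number from compound 1 to compound 3 (0.33 log units; beyond the scatter) varied only its alkyl part. Compound 4 is known only as a limit: the limit of > 2 h in this assay, at which 1 of the 4 values shown sits. With anilino in place of (oxolan-2-yl)methoxy on the carbonyl carbon, the comparison gives an at least 23-fold higher number from compound 2 to compound 4 (1.37 log units; beyond the scatter), and compound 2 is also known only as a limit: the limit of < 0.0834 h in this assay, at which 1 of the 4 values shown sits.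

Going by these compounds, the actual half-life of compound 4 stays open, so the full size of these steps is not fixed. A carboxylic acid or a methoxy group on the same aromatic carbon would test whether the short half-life follows the isopropoxycarbonyl and sec-butoxycarbonyl groups specifically or any group other than hydrogen there.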